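Lengthening a hydroxyalkyl ether by one carbon

The source may hold more compounds than are shown below. What is called first, only, known or untested is meant among the compounds shown, and "the series" means these compounds.

Three measured compounds share one core and differ only in the group on an oxygen on a saturated carbon. Compound 1 `CC(C)=CC[C@@H](OC(=O)c1ccco1)C1=CC(=O)c2c(O)ccc(O)c2C1=O` carries a (furan-2-yl)carbonyl there. In a functional assay on DU-145 cells (Homo sapiens) for cytotoxicity, read by MTT assay (a lower number here means a stronger inhibitor, a higher number a weaker inhibitor), compound 1 reaches only a limit, > 100000 nM, and gives no number (the limit of > 100000 nM in this assay, at which 1 of the 3 values shown sits). Compound 2 `CC(C)=CC[C@@H](OC[C@@H](C)O)C1=CC(=O)c2c(O)ccc(O)c2C1=O` bears a 2-hydroxypropyl, and in this assay compound 2 gives 14300 nM, the lowest of the two numbers measured. Compound 3 `CC(=O)OCCO[C@H](CC=C(C)C)C1=CC(=O)c2c(O)ccc(O)c2C1=O` bears a 2-acetoxyethyl, and in this assay compound 3 gives 15500 nM; the two numbers sit close, a 1.1-fold higher number from compound 2 to compound 3 (0.03 log units; within the scatter). Both of these ethers leave the limit behind: an at least 6.9-fold lower number from compound 1 to compound 2 (0.84 log units; beyond the scatter) and an at least 6.4-fold lower number from compound 1 to compound 3 (0.80 log units; beyond the scatter).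

Compound 4 `CCC(O)CO[C@H](CC=C(C)C)C1=CC(=O)c2c(O)ccc(O)c2C1=O` has not been measured. It differs from compound 2 in one place: 1-hydroxypropyl in place of 1-hydroxyethyl on a saturated chain carbon bound to an oxygen on a saturated carbon. Among the compounds with values here, the only measured step at that saturated chain carbon, a 1.1-fold higher number from compound 2 to compound 3 (0.03 log units; within the scatter), stayed within the scatter even when acetoxymethyl replaced 1-hydroxyethyl; the change to compound 4 adds a single carbon and keeps the hydrogen-bond donor, so no step beyond the scatter is expected in this assay, in either direction. Compound 4 is therefore expected to give 14000 nM in this assay, between 6000 nM and 35000 nM. This estimate means an expected step of a 1.0-fold lower number from compound 2 to compound 4 (0.01 log units; within the scatter).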

Compound 4, half-maximal inhibitory concentration: 16400 nM
The estimate for compound 4 lay 1.2-fold (0.07 log units) below the measured number; low and high end bracket the measured number.
By their numbers in this assay, from the lowest: compounds 2, 3 and 4 (each within the scatter of the next). At a limit, above all of these: compound 1.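

In this assay the 2-hydroxybutyl leaves the number where the 2-hydroxypropyl had it, a 1.1-fold higher number from compound 2 to compound 4 (0.06 log units; within the scatter) and the same holds against the 2-acetoxyethyl, a 1.1-fold higher number from compound 3 to compound 4 (0.02 log units; within the scatter) so the saturated chain carbon bound to the ether oxygen accepts a 1-hydroxypropyl as well as the 1-hydroxyethyl and the acetoxymethyl. Within the data shown here, this is the first step here that changes the chain while keeping the hydrogen-bond donor, and it stays within the scatter, so the three ethers now form one group in this assay, and the separation from the (furan-2-yl)carbonyl holds for the new ether too, an at least 6.0-fold lower number from compound 1 to compound 4 (0.78 log units; beyond the scatter) as it did for the other two. Compound 1 remains the only limit among the four: the limit of > 100000 nM in this assay, at which 1 of the 4 values shown sits.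

The 1-hydroxyethyl carries a defined stereocentre and the 1-hydroxypropyl does not, so what that centre contributes cannot be read from these compounds. Going by these compounds, whether a longer chain, an amine or a carboxylic acid at this saturated chain carbon would stay in the same range also remains open.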